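Urea Substituent Change on an Imidazothiazole Indoleamine Dioxygenase Inhibitor

The compounds below may be only part of what the source reports. "The series", "measured", "known", "first", "only" and "open" are said of these compounds alone.

The measured compounds:
compound 1 `O=C(NCc1cnc2scc(-c3ccc(Br)cc3)n12)NC1CCCCC1`: 1800 nM
compound 2 `CCOC(=O)c1cnc2scc(C3=CCCCC3)n12`: > 100000 nM
compound 3 `CCOC(=O)c1cnc2scc(Cc3ccccc3)n12`: > 100000 nM

Among the measured compounds shown here, compound 1 `O=C(NCc1cnc2scc(-c3ccc(Br)cc3)n12)NC1CCCCC1` is the only compound among the three that gives a number in an assay on isolated protein for inhibition of Indoleamine 2,3-dioxygenase 1 (Homo sapiens), with a stated time of 30 min; on this read-out lower numbers stand for stronger inhibition and higher numbers for weaker inhibition; in this assay compound 1 gives 1800 nM. For compound 2 `CCOC(=O)c1cnc2scc(C3=CCCCC3)n12` this assay reports only a limit, > 100000 nM. For compound 3 `CCOC(=O)c1cnc2scc(Cc3ccccc3)n12` the same holds, with the limit > 100000 nM. Both sit at the limit of > 100000 nM in this assay, at which 2 of the 3 values shown sit.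

Compound 4 `O=C(NCc1cnc2scc(-c3ccc(Br)cc3)n12)Nc1ccccc1` differs from compound 1 by phenyl in place of cyclohexyl on an amide-type nitrogen. For the measured compounds named here, no measured pair shows this change, so the step from compound 1 to compound 4 is expected to lie within the usual scatter, with no clear direction; the expected step is a 1.2-fold lower number from compound 1 to compound 4 (0.08 log units; within the scatter). Compound 4 is therefore estimated at 1500 nM, in a range from 500 nM to 5000 nM.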

Compound 4, half-maximal inhibitory concentration: 220 nM
Compound 4: middle estimate off by 6.8-fold (0.83 log units), on the high side, and the stated range ends above it.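

On this amide-type nitrogen, phenyl in place of cyclohexyl gives an 8.2-fold lower number from compound 1 to compound 4 (0.91 log units; beyond the scatter) in this assay, so this position responds to the kind of ring it carries, although both groups have the same count of heavy atoms. No other pair shown differs in one place, so this step is the only direct reading of the position. Nothing shown accounts for the size of this step. On these data alone, it remains open how a pyridine ring, a benzyl group or a methoxy-substituted phenyl would behave on this nitrogen. Also open, as far as these compounds go, is whether the step would hold with another group in place of the bromine.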